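The source may hold more compounds than are shown below. What is called first, only, known or untested is meant among the compounds shown, and "the series" means these compounds.

Measured compounds:
Compound 1, `COc1ccc(-c2ccc(C)n2-c2ccc(-c3nc4ccccc4s3)cc2)cc1`, 14800 nM in a functional assay on MDA-MB-231 cells (Homo sapiens) for cytotoxicity, read by MTT assay, with a stated time of 72 h; a higher number here means a weaker inhibitor, a lower number a stronger inhibitor.
Compound 2, `Cc1ccc(-c2ccc([N+](=O)[O-])cc2)n1-c1ccc(-c2nc3ccccc3s2)cc1`, 12100 nM in this assay.
Compound 3, `COc1ccc(-c2ccc(C)n2-c2ccc(-c3nc4ccc(OC)cc4s3)cc2)cc1`, 12700 nM in this assay.

All three numbers lie within the usual scatter of one another, so no order among them can be read. The change from compound 1 to compound 2 is nitro in place of methoxy on an aromatic carbon; it gave a 1.2-fold lower number from compound 1 to compound 2 (0.09 log units; within the scatter).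

Compound 4, `COc1ccc2nc(-c3ccc(-n4c(C)ccc4-c4ccc([N+](=O)[O-])cc4)cc3)sc2c1`, is not yet measured in this assay. It differs from compound 3 by nitro in place of methoxy on an aromatic carbon, the same change as from compound 1 to compound 2, made on a different core. The two cores differ by methoxy in place of hydrogen on an aromatic carbon, a change that in this assay gave a 1.2-fold lower number from compound 1 to compound 3 (0.07 log units; within the scatter).

Since the earlier step was within the scatter and the cores differ only by a methoxy group, the step from compound 3 to compound 4 is expected to be of similar size, about a 1.2-fold lower number from compound 3 to compound 4 (0.08 log units; within the scatter). Compound 4 is thus estimated at 10500 nM in this assay, with a likely range from 5000 nM to 22000 nM.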

Compound 4, half-maximal inhibitory concentration: 12700 nM
Compound 4: the middle estimate sits 1.2-fold (0.08 log units) below what was measured; low and high end bracket the measured number.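

In this assay, nitro in place of methoxy carries from one core to the other with no readable difference between the two steps: the same change on two cores in this assay, a 1.2-fold lower number (0.09 log units; within the scatter) from compound 1 to compound 2 and no change at the digits printed (within the scatter) from compound 3 to compound 4, 1.2-fold (0.09 log units) apart, within the scatter of two such steps. Methoxy in place of hydrogen also carries across the two cores with no readable difference: the same change on two cores in this assay, a 1.2-fold lower number (0.07 log units; within the scatter) from compound 1 to compound 3 and a 1.0-fold higher number (0.02 log units; within the scatter) from compound 2 to compound 4, 1.2-fold (0.09 log units) apart, within the scatter of two such steps. Among the compounds shown here, the new steps, no change at the digits printed from compound 3 to compound 4 (within the scatter) and a 1.0-fold higher number from compound 2 to compound 4 (0.02 log units; within the scatter), show only that neither change moves the number beyond the scatter on these cores; they do not show that the two changes add up or cancel, or that either has any real effect, and they say nothing about a change large enough to read.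

The compounds shown leave open whether an amine or a carboxylic acid in the place of the methoxy or nitro group would shift the number beyond the scatter. They also leave open what a longer chain in place of the methoxy group would do in this series.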